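Working notes: removing the isopropyl from compound 1

The source may hold more compounds than are shown below. What is called first, only, known or untested is meant among the compounds shown, and "the series" means these compounds.

Measured so far in a functional assay on SAS cells (Homo sapiens) for cytotoxicity, read by MTT assay, with a stated time of 48 h; a lower number here means a stronger inhibitor, a higher number a weaker inhibitor
Compound 1 `COC(=O)[C@@H](NC(=O)CSC1=CC(=O)c2cccc(OC)c2C1=O)C(C)C` gives 45000 nM
Compound 2 `COC(=O)[C@@H](NC(=O)CSC1=C(C)C(=O)c2ccccc2C1=O)C(C)C` gives 16000 nM

Compound 1 holds the higher of the two numbers, and compound 2 lies lower by more than the usual scatter. These two compounds differ in more than one place, so their gap does not isolate any single change. Going from compound 1 to compound 3 `COC(=O)CNC(=O)CSC1=CC(=O)c2cccc(OC)c2C1=O` puts hydrogen in place of isopropyl on a saturated chain carbon bound to an amide-type nitrogen and a carbonyl carbon. For the measured compounds named here, no measured pair shows this change, so the expectation rests on weak ground. In this assay no shift beyond the scatter is expected, with only a slight move toward a higher number. The estimated step of a 1.1-fold higher number from compound 1 to compound 3 (0.05 log units; within the scatter) is therefore small. For compound 3 the expected value is 50000 nM (estimated range 20000 nM to 120000 nM).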

Compound 3, half-maximal inhibitory concentration: > 100000 nM
Compound 3: no number, only a limit (the forecaster's own chance of this, stated with the estimate: 10%); middle value at least 2.0-fold (0.30 log units) away from the limit.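

For the compounds shown here, replacing isopropyl with hydrogen on the saturated chain carbon bound to an amide-type nitrogen and a carbonyl carbon gives an at least 2.2-fold higher number from compound 1 to compound 3 (0.34 log units; beyond the scatter) in this assay and is the first change confined to one place. Compound 3 carries a limit and not a number, and the step is a lower bound only: the limit of > 100000 nM in this assay, at which 1 of the 3 values shown sits. On the core of compound 1 this position is therefore not indifferent to the change, and the isopropyl goes with the stronger of the two results.

One pair cannot show whether the size of the group at this place tracks the read-out, and a methyl, a benzyl or a longer chain there would test that. As far as these compounds go, whether the same change behaves alike on the core of compound 2 also stays open, as does a carboxylic acid in place of the methyl ester.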